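This account rests on a few compounds, and the source may have more. Where it says the series, first, only, none or still open, it means among the compounds named here.

In a physicochemical assay for solubility, using the shake flask method, in phosphate buffer, measured as thermodynamic solubility, with a stated time of 16 h, at pH 6.8 (on this read-out higher numbers stand for higher solubility and lower numbers for lower solubility), compound 1 `COc1cc(C(=O)O)c(NC(=O)N[C@@H](C)c2ccccc2)cc1OCCCC(C)C` gives a measured number, 728000 nM. Compound 3 `COc1ccc(NC(=O)N[C@@H](C)c2ccccc2OC)cc1OCCCC(C)C` gives only a limit, <= 4000 nM, and that limit is all that is known of where it stands. Compound 4 `COc1ccc(NC(=O)N[C@@H](C)c2ccccc2)cc1OCCCC(C)C` has not yet been measured. It differs from compound 3 by hydrogen in place of methoxy on an aromatic carbon, ortho to a large group (hydrogen in place of methoxy on an aromatic carbon). Within the data shown here, no measured pair shows this change, so no shift beyond the scatter is expected in this assay, and neither direction is favoured. The expectation leans on compound 2 `CCCCCCOc1cc(NC(=O)N[C@@H](C)c2ccccc2)ccc1OC`, which also carries phenyl rather than 2-methoxyphenyl and gives only the limit < 4000 nM. The expected step is a step that the limit leaves unreadable from compound 3 to compound 4. For compound 4 the estimated value is 3500 nM, with an expected range of 1500 nM to 8000 nM.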

Compound 4, solubility: < 4000 nM
Compound 4: only a limit was reported; the forecaster's own chance of this, stated with the estimate: 70%; the middle value is on the limit's open side.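

In this assay, removing the carboxy group gives an at least 180-fold lower number from compound 1 to compound 4 (2.26 log units; beyond the scatter) and this is the only step among these compounds with a readable size. Hydrogen in place of methoxy shows no measurable shift: compound 4 gives only a limit, and the steps from compound 3 and from compound 2 to compound 4 cannot be read: the limit of < 4000 nM in this assay, at which 2 of the 4 values shown sit.

Going by these compounds, the size of the change from 2-methoxyphenyl to phenyl stays open. On these data alone, it also stays open whether an amine or a sulfonic acid in place of carboxy would give a number clear of the limit.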